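Swapping the Aryl Group Beside a Covalent Warhead

The compounds below may be only part of what the source reports. "The series", "measured", "known", "first", "only" and "open" are said of these compounds alone.

Compound 1 `C=C(Br)C(=O)Nc1cccc(-c2cn3nc(Cc4cccc(OC)c4)sc3n2)c1` gives 1100 nM
Compound 2 `Nc1cccc(-c2cn3nc(CCc4ccccc4)sc3n2)c1` gives 29000 nM
Compound 3 `COc1ccc(-c2nn3cc(-c4cccc(N)c4)nc3s2)cc1OC` gives 13000 nM

The three measured compounds share a core and were tested in a functional assay on FM3A cells (Mus musculus) for inhibition, read by cell counting, with a stated time of 2 days; a lower number here means a stronger inhibitor, a higher number a weaker inhibitor. Compound 1 stands lowest of the three numbers in this assay. Its nearest neighbour is compound 3, whose value is higher by a margin well beyond the usual scatter, and the furthest is compound 2, higher again. Compounds 2 and 3 both carry a free amine where compound 1 carries a 2-bromoacrylamide, and both also differ from compound 1 in the group on the five-membered ring, so no single change can be read from their values.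

Compound 4 `C=C(Br)C(=O)Nc1cccc(-c2cn3nc(-c4ccc(C)cc4)sc3n2)c1` keeps the 2-bromoacrylamide of compound 1 and differs only in one place: 4-methylphenyl in place of 3-methoxybenzyl on an aromatic carbon. Among the compounds with values here, no measured pair isolates this change. Compound 3, which carries an aryl group directly on the ring, sits below compound 2, which carries a two-carbon chain to its aryl, but other differences are mixed into that comparison. A step of at most moderate size in either direction, likely within the scatter, is expected for this assay.

Compound 4 is therefore expected to give 1500 nM, within a range of 400 nM to 6000 nM, a step of a 1.4-fold higher number from compound 1 to compound 4 (0.13 log units; within the scatter) that is estimated to stay close to the scatter.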

Compound 4, half-maximal inhibitory concentration: 1200 nM
Compound 4: the middle estimate sits 1.3-fold (0.10 log units) above what was measured; low and high end bracket the measured number.
By their numbers in this assay, from the lowest: compounds 1 and 4 (each within the scatter of the next); then compound 3; then compound 2.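

Set in this assay, the exchange of 3-methoxybenzyl for 4-methylphenyl on this aromatic carbon gives a 1.1-fold higher number from compound 1 to compound 4 (0.04 log units; within the scatter), so with the 2-bromoacrylamide held fixed, this read-out does not separate the two groups. Within the data shown here, this is the first pair in the set that differs in one place, and it shows that the position can carry a phenyl ring attached directly as well as a benzyl group, with no step beyond the scatter, even though the entering group has fewer heavy atoms and no hydrogen-bond acceptor. Nothing measured here accounts for the two groups giving matching numbers.

The compounds shown leave open what happens at this position when the six-membered aromatic ring of carbon only gives way to something else, such as a morpholine, a carboxylic acid or a plain alkyl chain. They also leave open how much the 2-bromoacrylamide itself contributes compared with a free amine, as no pair shown differs in that place alone.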